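The source may report more compounds than this note shows. Statements on the series, on what has been measured and on what is new or still open speak of the compounds shown alone.

Compound 1 `CN(C)c1nc(N)nc2c1ncn2/C=C1/CC1(CO)CO`: > 20000 nM, a limit
Compound 2 `CCCCNc1nc(N)nc2c1ncn2/C=C1/CC1(CO)CO`: > 20000 nM, a limit

In an ADME assay on CCRF-HSB-2 cells (Homo sapiens) for cytotoxicity, with a stated time of 7 days (on this read-out lower numbers stand for higher toxicity in this test and higher numbers for lower toxicity in this test), compound 2 gives > 20000 nM, which is a limit of the assay and not a number. Compound 2 therefore has no exact position and sits at the limit of > 20000 nM in this assay, at which 2 of the 2 values shown sit.

Compound 3 `Nc1nc(SCc2ccccc2)c2ncn(/C=C3/CC3(CO)CO)c2n1` carries benzylsulfanyl in place of butylamino on an aromatic carbon.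

For the measured compounds named here, the only measured step bearing on this change is a step that the two limits leave unreadable from compound 1 to compound 2. Going by the values given here, it also swaps the group at an aromatic carbon, but it gives no size to carry over, and no measured compound has benzylsulfanyl. Any firm direction would therefore be a guess, so this assay is expected to show little beyond the scatter, with some room for higher toxicity. The expected change is a number no higher from compound 2 to compound 3 (the limit leaves the size open). The estimate for compound 3 is 20000 nM, with an expected range from 7000 nM to 40000 nM.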

Compound 3, half-maximal cytotoxic concentration: > 100000 nM
Compound 3 gave a limit, no number; the forecaster's own chance of this, stated with the estimate: 70%; middle value at least 5.0-fold (0.69 log units) away from the limit.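

For the compounds shown here, compound 1, compound 2 and compound 3 each end at a limit of the test and not at a number, so no step among them can be read. The compounds shown leave open whether changing the group on this aromatic carbon alters toxicity at all, and at what concentration any of them becomes toxic.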